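Replacing 3-Fluorophenoxy with Chloro on the Shared Core

The source may report more compounds than this note shows. Statements on the series, on what has been measured and on what is new or still open speak of the compounds shown alone.

Measured compounds:
compound 1 `Cc1nnsc1CO/N=C/c1c(C)nn(C)c1Oc1cccc(F)c1` — > 50000 nM
compound 2 `Cc1nnsc1CO/N=C/c1c(C)nn(C)c1Oc1cccc(C(F)(F)F)c1` — 12400 nM
compound 3 `Cc1nnsc1CO/N=C/c1c(C)nn(C)c1Oc1cc(F)cc(F)c1` — 9410 nM

In a functional assay on SGC-7901 cells (Homo sapiens) for inhibition, read by MTT assay, with a stated time of 48 h (a higher number here means a weaker inhibitor, a lower number a stronger inhibitor), compound 1 gives > 50000 nM, which is a limit of the assay rather than a number. Compound 2 gives 12400 nM in this assay. Compound 3 gives 9410 nM in this assay. Both measured steps therefore move from the limit to a number: an at least 4.0-fold lower number from compound 1 to compound 2 (0.60 log units; beyond the scatter) and an at least 5.3-fold lower number from compound 1 to compound 3 (0.72 log units; beyond the scatter). Compound 1 stands at the limit of > 50000 nM in this assay, at which 1 of the 3 values shown sits, the weakest position the numbers allow.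

Compound 4 `Cc1nnsc1CO/N=C/c1c(C)nn(C)c1Cl` differs from compound 1 in one place: chloro in place of 3-fluorophenoxy on an aromatic carbon. The two measured steps bear on it only loosely, since each kept the phenoxy ring and changed a substituent on it, whereas here the whole ring leaves and a single chloro enters. Going by the values given here, no measured pair removes that ring, so there is no direct precedent. Compound 1 already sits at the limit, and the change in compound 4 is of a different kind from the steps that improved potency, so compound 4 is expected to remain a weak inhibitor, with a number no higher from compound 1 to compound 4 (the limit leaves the size open) being the expected step. The estimate for compound 4 is 50000 nM, with a range from 15000 nM to 200000 nM, and a fair chance that only a limit is reported.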

Compound 4, half-maximal inhibitory concentration: > 50000 nM
Compound 4: a limit, no number; the forecaster's own chance of this, stated with the estimate: 60%; the middle value sits exactly at the limit.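

In this assay compound 4 gives > 50000 nM, which is a limit and not a number. Compound 1 also stands at a limit, so the step between these two compounds cannot be read: the limit of > 50000 nM in this assay, at which 2 of the 4 values shown sit. The compounds shown leave open whether chloro in place of 3-fluorophenoxy changes inhibition at all, and by how much.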